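Amine swap on the shared core in adenosine A2b displacement

This account rests on a few compounds, and the source may have more. Where it says the series, first, only, none or still open, it means among the compounds named here.

Measured compounds:
compound 1 `CN1CCN(c2nc(-c3cc(Cl)ccc3Cl)nc3[nH]cnc23)CC1` — 13%
compound 2 `Oc1cccc(-c2nc(N3CCCCC3)c3nc[nH]c3n2)c1` — > 80%

In an assay on cells for displacement of a labelled ligand from adenosine receptor A2b (Homo sapiens), read by scintillation counting and radioligand binding, with a stated time of 30 min, tested at 10 uM (on this read-out higher numbers stand for more inhibition at the one concentration tested (going by the name of the read-out) and lower numbers for less inhibition), compound 1 gives 13%. In this assay compound 2 gives > 80%, which is a limit of the assay and not a number; here the reading reaches (the limit of > 80% in this assay, at which 1 of the 2 values shown sits). Compound 3 `CN1CCN(c2nc(-c3cccc(O)c3)nc3[nH]cnc23)CC1` is not yet measured; it differs from compound 2 by 4-methylpiperazin-1-yl in place of piperidin-1-yl on an aromatic carbon. Compound 1 carries the same 4-methylpiperazin-1-yl group and sits low in this assay, but its other substituent differs as well, so no step can be read from that pair. The step in this assay is expected downward, beyond the scatter, estimated as a number at least 25 percentage points lower from compound 2 to compound 3 (beyond the scatter). Compound 3 is expected to give 55%, between 25% and 85%.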

Compound 3, a percentage reported as inhibition, at one concentration (the size of the read-out at that concentration, not a potency): 27%
Compound 3: middle estimate off by 28 percentage points, on the high side, within the range that was stated.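

With the 3-hydroxyphenyl group held, 4-methylpiperazin-1-yl in place of piperidin-1-yl at this position gives a number at least 53 percentage points lower from compound 2 to compound 3 (beyond the scatter) in this assay, so the amine alone sets much of the reading here. The reading of compound 2 is a limit of the assay and not a number, so that step is a bound only: the limit of > 80% in this assay, at which 1 of the 3 values shown sits. With 4-methylpiperazin-1-yl held, 3-hydroxyphenyl in place of 2,5-dichlorophenyl gives a number 14 percentage points higher from compound 1 to compound 3 (beyond the scatter) as a smaller gain on the aryl side.

On these data alone, whether the drop follows the second ring nitrogen or its methyl group stays open; piperazin-1-yl without the methyl, or morpholin-4-yl, would separate the two. As far as these compounds go, how piperidin-1-yl reads alongside 2,5-dichlorophenyl also stays open.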